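Methyl-for-ethyl at the side chain of compound 3

This account rests on a few compounds, and the source may have more. Where it says the series, first, only, none or still open, it means among the compounds named here.

Compounds measured in a functional assay on the whole organism (strain Swiss) with Mus musculus as the target, with a stated time of 0.25 h; a higher number here means that more compound is needed for the effect, a lower number that less compound is needed:
- compound 1 `CCC(C(=O)N1CCN(c2cccc(C(F)(F)F)c2)CC1)N1C(=O)CC(C)C1=O` gives 30.3 mg/kg
- compound 2 `Cc1cccc(N2CCN(C(=O)C(C)N3C(=O)CC(C)C3=O)CC2)c1` gives "not determined" (no result reported), that is, no result reported
- compound 3 `CCC(C(=O)N1CCN(c2cccc(Cl)c2)CC1)N1C(=O)CC(C)C1=O` gives 43.5 mg/kg

Compound 3 carries the highest of the two numbers recorded in this assay; its nearest neighbour is compound 1, and the step of a 1.4-fold higher number from compound 1 to compound 3 (0.16 log units; within the scatter) lies within the scatter, so the two are not distinguishable on the numbers. Compound 2 adds nothing to this comparison, since no result was reported for it.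

The next compound, compound 4 `CC1CC(=O)N(C(C)C(=O)N2CCN(c3cccc(Cl)c3)CC2)C1=O`, differs from compound 3 by hydrogen in place of methyl on a saturated chain carbon, two bonds along the chain from an amide-type nitrogen in a ring and a carbonyl carbon. Among the measured compounds shown here, no measured step in this assay touches that position: the only step recorded, from compound 1 to compound 3, concerns the aromatic substituent and was within the scatter. Compound 2, which carries the shorter chain, would have been the nearest guide, but it has no number. In the absence of any relevant step, the working expectation is that compound 4 will show no change beyond the scatter, so the expected step is a 1.0-fold lower number from compound 3 to compound 4 (0.01 log units; within the scatter).

Compound 4 is therefore estimated at 43 mg/kg in this assay, with a range of 20 mg/kg to 95 mg/kg.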

Compound 4, dose for half-maximal effect: 13.6 mg/kg
For compound 4 the middle estimate is 3.2-fold (0.50 log units) above the measured one; measured number below the stated range.
By their numbers in this assay, from the lowest: compound 4; then compounds 1 and 3 (each within the scatter of the next).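

In this assay, among the compounds shown here, this side-chain carbon is the first position where a single change moves the number beyond the scatter: ethyl to methyl gives (a 3.2-fold lower number from compound 3 to compound 4 (0.50 log units; beyond the scatter)). For the compounds shown here, the only earlier step, at the aromatic substituent (a 1.4-fold higher number from compound 1 to compound 3 (0.16 log units; within the scatter)), stayed within the scatter, so the compounds with numbers now show a response to the change at the chain and none that can be separated from scatter at the ring substituent. No measured evidence bears on why the shorter chain goes with the lower number.

As far as these compounds go, the methyl side chain can be read only with the chloro substituent, so whether the step carries over to the trifluoromethyl compounds stays open. From the compounds shown here alone, how a propyl chain or a hydroxymethyl group at this carbon would read in this assay also stays open.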